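A third methoxy group on the ring of compound 3

The source may report more compounds than this note shows. Statements on the series, on what has been measured and on what is new or still open speak of the compounds shown alone.

Compound 1 `COc1ccc(/C=C2\Cc3c(cc(OC)c(OC)c3OC)C2=O)cc1[N+](=O)[O-]`: 1560 nM
Compound 2 `COc1ccc(/C=C2\Cc3c(cc(OC)c(OC)c3OC)C2=O)cc1`: 750 nM
Compound 3 `COc1ccc(/C=C2\Cc3c(cc(OC)c(OC)c3OC)C2=O)cc1OC`: 7470 nM

In a functional assay on PC-3 cells (Homo sapiens) for antiproliferative activity, read by MTT assay, with a stated time of 48 h (a lower number here means a stronger inhibitor of growth, a higher number a weaker inhibitor of growth), compound 3 gives the highest of the three numbers, so it is the weakest growth inhibitor here; the nearest is compound 1 and the furthest is compound 2. Compound 4 `COc1cc(/C=C2\Cc3c(cc(OC)c(OC)c3OC)C2=O)cc(OC)c1OC` differs from compound 3 by a single change: methoxy in place of hydrogen on an aromatic carbon. The step that bears most directly on this is a 10-fold higher number from compound 2 to compound 3 (1.00 log units; beyond the scatter), where the same kind of change was made, and a 4.8-fold higher number from compound 1 to compound 3 (0.68 log units; beyond the scatter) also went upward. A further rise is therefore expected, a 2.0-fold higher number from compound 3 to compound 4 (0.30 log units; within the scatter), with some uncertainty. Compound 4 is estimated at 15000 nM, in the range 4000 nM to 60000 nM.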

Compound 4, concentration for 50% growth inhibition: 4990 nM
Beside the measured number, compound 4's estimate is 3.0-fold (0.48 log units) above it; measured number inside the range.
By their numbers in this assay, from the lowest: compound 2; then compound 1; then compounds 4 and 3 (each within the scatter of the next).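

In this assay, placing methoxy in place of hydrogen on the aromatic carbon ortho to a methoxy group gives a 1.5-fold lower number from compound 3 to compound 4 (0.18 log units; within the scatter), so at this position the added group brings no change that can be told from scatter. The same kind of change elsewhere on this ring gave a 10-fold higher number from compound 2 to compound 3 (1.00 log units; beyond the scatter), so one such step does not foretell the next. Nothing available here explains why the two steps differ. On these data alone, whether a hydroxyl group, an amine or a fluorine atom would be accepted at this position remains open.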